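Swapping the anilide aryl group for a difluorobenzyl group

This account rests on a few compounds, and the source may have more. Where it says the series, first, only, none or still open, it means among the compounds named here.

Of the compounds shown here, three sharing one core have been tested in an ADME assay on HepG2 2.2.15 cells (Homo sapiens) for cytotoxicity, read by MTT assay, with stated times of 48 h and 9 days; on this read-out higher numbers stand for lower toxicity in this test and lower numbers for higher toxicity in this test. Compound 1 `COc1ccc2c(=O)c(/C=C/C(=O)Nc3ccc(C)cc3)coc2c1` gives 979000 nM, compound 2 `COc1ccc2c(=O)c(/C=C/C(=O)Nc3ccccc3OC)coc2c1` gives 1050000 nM, and compound 3 `COc1ccc(NC(=O)/C=C/c2coc3cc(OC)ccc3c2=O)cc1` gives 718000 nM. Compound 3 is separated from compound 1 by a 1.4-fold lower number from compound 1 to compound 3 (0.13 log units; within the scatter) and from compound 2 by a 1.5-fold lower number from compound 2 to compound 3 (0.17 log units; within the scatter), so the three numbers cannot be told apart. Compound 4 `COc1ccc2c(=O)c(/C=C/C(=O)NCc3ccc(F)cc3F)coc2c1` differs from compound 3 by 2,4-difluorobenzyl in place of 4-methoxyphenyl on an amide-type nitrogen. Among the compounds with values here, every measured step so far, including a 1.1-fold higher number from compound 1 to compound 2 (0.03 log units; within the scatter), exchanged one aromatic ring on the amide nitrogen for another and stayed within the scatter; none covers a benzyl group, so the bearing is indirect. For compound 4 the expected step is a 1.2-fold higher number from compound 3 to compound 4 (0.07 log units; within the scatter), essentially no change beyond the scatter. Compound 4 is therefore estimated at 850000 nM, within 400000 nM to 1500000 nM.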

Compound 4, half-maximal cytotoxic concentration: 79300 nM
The estimate for compound 4 lay 11-fold (1.03 log units) above the measured number; the measured number lies below the stated range.
By their numbers in this assay, from the lowest: compound 4; then compounds 3, 1 and 2 (each within the scatter of the next).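

In this assay this position on the amide nitrogen turns out to be sensitive: 2,4-difluorobenzyl gives a 9.1-fold lower number from compound 3 to compound 4 (0.96 log units; beyond the scatter) and also a 13-fold lower number from compound 2 to compound 4 (1.12 log units; beyond the scatter) and a 12-fold lower number from compound 1 to compound 4 (1.09 log units; beyond the scatter) and so marks higher toxicity in this test. The earlier exchanges among 4-methylphenyl, 2-methoxyphenyl and 4-methoxyphenyl showed no such shift. Nothing available explains this drop.

From the compounds shown here alone, whether the shift follows the benzyl group itself or its two fluorines remains open. A plain benzyl group on the same nitrogen would separate the two.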